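Sulfonyl to carbonyl on the shared core

The source may report more compounds than this note shows. Statements on the series, on what has been measured and on what is new or still open speak of the compounds shown alone.

In a functional assay on MKN-45 cells (Homo sapiens) for cytotoxicity (on this read-out lower numbers stand for stronger inhibition and higher numbers for weaker inhibition), compound 3 `COc1ccc(S(=O)(=O)N2CCc3cccc(NS(=O)(=O)c4ccccc4)c32)cc1` gives 562 nM. Compound 2 `COC(=O)c1ccc(C(=O)Nc2cccc3c2N(S(=O)(=O)c2ccc(OC)cc2)CC3)cc1` gives 312 nM, which lies within the scatter of the value for compound 3, while compound 1 `COc1ccc(S(=O)(=O)N2CCc3cccc(NC(=O)c4cccs4)c32)cc1` gives 31 nM.

The next compound, compound 4 `COc1ccc(C(=O)Nc2cccc3c2N(S(=O)(=O)c2ccc(OC)cc2)CC3)cc1`, carries (4-methoxyphenyl)carbonyl in place of phenylsulfonyl on a nitrogen on an aromatic ring.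

For the measured compounds named here, two measured steps bear on this change. The first is an 18-fold higher number from compound 1 to compound 3 (1.26 log units; beyond the scatter), a large step with phenylsulfonyl in place of (thiophen-2-yl)carbonyl, and it suggests that a lower number may return with a carbonyl. The second is a 10-fold higher number from compound 1 to compound 2 (1.00 log units; beyond the scatter), a modest step with 4-(methoxycarbonyl)phenyl in place of thiophen-2-yl on a carbonyl carbon, and it tempers that hope. Like compound 4, compound 2 has a substituted phenyl on its carbonyl, yet compound 2 gives 312 nM. Going by the values given here, no measured compound shows what the 4-methoxyphenyl group itself does.

A modest move towards a lower number is therefore expected in this assay, estimated as a 3.7-fold lower number from compound 3 to compound 4 (0.57 log units; beyond the scatter). The estimate for compound 4 is 150 nM, with an expected range from 40 nM to 500 nM.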

Compound 4, half-maximal inhibitory concentration: 1600 nM
The estimate for compound 4 lay 11-fold (1.03 log units) below the measured number; the measured number lies above the stated range.
By their numbers in this assay, from the lowest: compound 1; then compounds 2 and 3 (each within the scatter of the next); then compound 4.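

In this assay, a carbonyl on this nitrogen does not by itself bring a lower number: with (4-methoxyphenyl)carbonyl in place of phenylsulfonyl there is a 2.8-fold higher number from compound 3 to compound 4 (0.45 log units; beyond the scatter), so the outcome at this position cannot be read from the carbonyl alone. The group on the carbonyl carbon weighs heavily, as 4-methoxyphenyl in place of thiophen-2-yl gives a 52-fold higher number from compound 1 to compound 4 (1.71 log units; beyond the scatter), the widest gap among these compounds and one that places compound 1 well apart from compound 4. The earlier compounds shown here also gave no view of a substituent on the phenyl ring, and methoxy in place of methoxycarbonyl on an aromatic carbon now gives a 5.1-fold higher number from compound 2 to compound 4 (0.71 log units; beyond the scatter), which shows that this one group alone moves the number clearly.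

No available evidence accounts for these shifts in the cytotoxicity numbers. From the compounds shown here alone, it remains open whether an amine or a carboxylic acid in place of methoxy on that aromatic carbon would bring the number closer to that of compound 1, and whether thiophen-2-yl would keep its low number on a sulfonyl rather than a carbonyl.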